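Shifting a Chlorine Atom: From Compound 2 to Compound 3

This account rests on a few compounds, and the source may have more. Where it says the series, first, only, none or still open, it means among the compounds named here.

Measured compounds:
compound 1 `O=C(CN1CCN(c2cc3c(cc2F)c(=O)c(C(=O)O)cn3C2CC2)CC1)Nc1ccc(C(=O)/C=C/c2ccccc2)cc1`: 6.4%
compound 2 `O=C(CN1CCN(c2cc3c(cc2F)c(=O)c(C(=O)O)cn3C2CC2)CC1)Nc1ccc(C(=O)/C=C/c2ccccc2Cl)cc1`: 4.2%

In an assay on isolated protein for inhibition of DNA topoisomerase 1 (Homo sapiens), with a stated time of 30 min, tested at 20 uM (on this read-out higher numbers stand for a stronger effect at the one concentration tested and lower numbers for a weaker effect), compound 1 gives 6.4% and compound 2 gives 4.2%. Compound 2 sits at the bottom of these two numbers with compound 1 nearest, yet the step of a number 2.2 percentage points lower from compound 1 to compound 2 (within the scatter) lies within the scatter, so the two cannot be told apart.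

Compound 3 `O=C(CN1CCN(c2cc3c(cc2F)c(=O)c(C(=O)O)cn3C2CC2)CC1)Nc1ccc(C(=O)/C=C/c2cccc(Cl)c2)cc1` differs from compound 2 by 3-chlorophenyl in place of 2-chlorophenyl on a double-bonded chain carbon bound to a double-bonded chain carbon. Among the compounds with values here, only one measured step bears on this, the addition of chlorine a number 2.2 percentage points lower from compound 1 to compound 2 (within the scatter), and it was small. A shift of the same chlorine is therefore expected to give a step of a number 0.8 percentage points higher from compound 2 to compound 3 (within the scatter), not beyond the scatter. Compound 3 is estimated at 5%, expected between 0% and 15%.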

Compound 3, a percentage reported as inhibition, at one concentration (the size of the read-out at that concentration, not a potency): 3.1%
Compound 3: the middle estimate sits 1.9 percentage points above what was measured, and the stated range covers the measured number.
By their numbers in this assay, from the lowest: compounds 3, 2 and 1 (each within the scatter of the next).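

Moving the chlorine around the ring gives a number 1.1 percentage points lower from compound 2 to compound 3 (within the scatter) in this assay, so the 2-chlorophenyl and 3-chlorophenyl groups cannot be told apart at this position. Compared with the unsubstituted phenyl of the parent, the new placement gives a number 3.3 percentage points lower from compound 1 to compound 3 (within the scatter), so neither chlorine placement can be separated from having no chlorine at all. No supporting measurement is available to explain these numbers. From the compounds shown here alone, it remains open whether an amine or a carboxylic acid on this aromatic ring, in place of chlorine, would give a step beyond the scatter.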